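Hydroxy to 3-hydroxypyrrolidin-1-yl: a small expected step

The source may report more compounds than this note shows. Statements on the series, on what has been measured and on what is new or still open speak of the compounds shown alone.

Compound 1 `COc1ccc(/C=C\c2cc(OC)c(OC)c(OC)c2)cc1OCc1ccc(CN2CCCCC2C(=O)O)cc1` gives 3100 nM
Compound 2 `COc1ccc(/C=C\c2cc(OC)c(OC)c(OC)c2)cc1OCc1ccc(CNCCO)cc1` gives 5900 nM
Compound 3 `COc1ccc(/C=C\c2cc(OC)c(OC)c(OC)c2)cc1OCc1ccc(CO)cc1` gives 2400 nM

In a functional assay on HepG2 cells (Homo sapiens) for antiproliferative activity, read by CCK-8 assay, with a stated time of 48 h (on this read-out higher numbers stand for weaker inhibition and lower numbers for stronger inhibition), compound 3 (2400 nM) stands level with compound 1 and clearly lower than compound 2. Compound 4 `COc1ccc(/C=C\c2cc(OC)c(OC)c(OC)c2)cc1OCc1ccc(CN2CC[C@H](O)C2)cc1` has 3-hydroxypyrrolidin-1-yl in place of hydroxy on a saturated chain carbon bound to an aromatic carbon. Bearing on this are a 2.5-fold lower number from compound 2 to compound 3 (0.39 log units; beyond the scatter) and a 1.3-fold lower number from compound 1 to compound 3 (0.11 log units; within the scatter) in the opposite direction, each replacing a nitrogen-bearing group with hydroxy at that carbon. Going by the values given here, no measured compound carries the new group itself. Reversed, these steps point to a small rise in this assay that may stay within the scatter, and a 1.7-fold higher number from compound 3 to compound 4 (0.22 log units; within the scatter) is expected. Compound 4 is estimated at 4000 nM (range 1800 nM to 9000 nM).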

Compound 4, half-maximal inhibitory concentration: 6600 nM
Compound 4: the middle estimate sits 1.7-fold (0.22 log units) below what was measured, within the range that was stated.
By their numbers in this assay, from the lowest: compounds 3, 1, 2 and 4 (each within the scatter of the next, the first and the last beyond it).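

Replacing hydroxy with 3-hydroxypyrrolidin-1-yl on this saturated chain carbon gives a 2.8-fold higher number from compound 3 to compound 4 (0.44 log units; beyond the scatter) in this assay, so a second nitrogen-bearing group stands clearly apart from hydroxy, as (2-hydroxyethyl)amino did. Against (2-hydroxyethyl)amino the ring makes no readable difference, at a 1.1-fold higher number from compound 2 to compound 4 (0.05 log units; within the scatter), yet 2-carboxypiperidin-1-yl stands apart from it, at a 2.1-fold higher number from compound 1 to compound 4 (0.33 log units; beyond the scatter), so nitrogen-bearing groups at this carbon do not all read alike. Nothing shown gives a cause for these gaps. Open, on these data alone, is how a plain piperidin-1-yl or a morpholine at this carbon would read, which would separate the carboxylic acid from the ring. Also open, as far as these compounds go, is whether the opposite stereoisomer of 3-hydroxypyrrolidin-1-yl would read the same.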